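The source may hold more compounds than are shown below. What is called first, only, known or untested is meant among the compounds shown, and "the series" means these compounds.

Of the compounds shown here, three sharing one core have been measured in a functional assay for activation of Alpha-1D adrenergic receptor (Homo sapiens), read by calcium flux; a higher number here means that more compound is needed for the effect, a lower number that less compound is needed. Compound 2, `c1ccc(-c2nccs2)c(OCC2=NCCN2)c1`, gives 31.6 nM. Compound 1, `c1cnc(-c2ccccc2OCC2=NCCN2)nc1`, reaches only a limit of the assay, < 100000 nM. Compound 3, `Cc1csc(-c2ccccc2OCC2=NCCN2)n1`, likewise reaches only a limit of the assay, < 100000 nM. Because of the limit of < 100000 nM in this assay, at which 2 of the 3 values shown sit, none of the steps among these three can be read in size: a step that the limit leaves unreadable from compound 1 to compound 2, a step that the two limits leave unreadable from compound 1 to compound 3 and a step that the limit leaves unreadable from compound 2 to compound 3 all remain unreadable. Among the measured compounds shown here, compound 3 thus stands at a limit and not at a number, with one further value in the set also at a limit and compound 2 the only numerical reading.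

Compound 4, `Cc1cnsc1-c1ccccc1OCC1=NCCN1`, is not yet measured. It differs from compound 3 by 4-methyl-1,2-thiazol-5-yl in place of 4-methyl-1,3-thiazol-2-yl on an aromatic carbon. For the measured compounds named here, no measured step bears directly on this rearrangement of the five-membered ring, and the steps leading to compound 3 are themselves unreadable, so no size or direction can be taken from them. Going by the values given here, what remains is that compound 2 is the only member with a number and the two heteroaryl variants around it sit at limits. The step is therefore estimated only loosely, as a step that the limit leaves unreadable from compound 3 to compound 4. Compound 4 is expected to give about 3000 nM in this assay, within a wide range of 100 nM to 100000 nM.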

Compound 4, half-maximal effective concentration: < 100000 nM
Compound 4: only a limit was reported (the forecaster's own chance of this, stated with the estimate: 40%); the middle value does not contradict the limit.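

Compound 4 also reaches only a limit of the assay, so no step from compound 1, compound 2 or compound 3 to compound 4 can be read in size, because of this limit: the limit of < 100000 nM in this assay, at which 3 of the 4 values shown sit.

The compounds shown leave open what numerical readings compound 1, compound 3 and compound 4 would give in this assay, and so how far each lies from compound 2.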